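Swapping acetyl for nitro where every reading is a limit

A few compounds are considered here, and "the series" means these few. Any claim that something is new, unique, unknown or untested is made for them only; others in the source may bear on it.

In an ADME assay on Raji cells (Homo sapiens) for cytotoxicity, read by luminescence, with a stated time of 72 h (a higher number here means that more compound is needed for the effect, a lower number that less compound is needed), compound 3 (`CCOC(=O)c1c(-c2cccc(C(C)=O)c2)[nH]c2cc(OC)ccc2c1=O`) gives > 21500 nM as its reading, which is a limit and not a number. Compound 1 (`CCOC(=O)c1c(-c2cc(F)cc(OC)c2)[nH]c2cc(OC)ccc2c1=O`) gives > 21500 nM as its reading, also a limit. Compound 2 (`CCCOc1cccc(-c2[nH]c3cc(OC)ccc3c(=O)c2C(=O)OCC)c1`) gives > 21500 nM as its reading, again a limit. All three thus share the limit of > 21500 nM in this assay, at which 3 of the 3 values shown sit, and no order among them can be read.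

Compound 4 (`CCOC(=O)c1c(-c2cccc([N+](=O)[O-])c2)[nH]c2cc(OC)ccc2c1=O`) keeps the shared core of compound 3 but carries nitro in place of acetyl on an aromatic carbon, meta to a large group: nitro in place of acetyl on an aromatic carbon is the whole difference.

Two measured steps reach the group that changes here: a step that the two limits leave unreadable from compound 1 to compound 3 and a step that the two limits leave unreadable from compound 2 to compound 3 are the ones to consult. Neither offers a size to carry over. With compound 3 reading > 21500 nM as a limit, no direction can be carried over either, so no step beyond the scatter is expected in this assay for this swap. The expected change is a step that the limit leaves unreadable from compound 3 to compound 4 on this estimate. Compound 4 is expected to read about 22000 nM with an estimated range from 9000 nM to 50000 nM and will most likely be reported only as a limit.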

Compound 4, half-maximal effective concentration: > 21500 nM
Compound 4 was reported as a limit; the forecaster's own chance of this, stated with the estimate: 85%; the middle value does not contradict the limit.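

No step can be read between compound 4 and compound 1, compound 2 or compound 3 in this assay, where all four readings are the same limit and not numbers: the limit of > 21500 nM in this assay, at which 4 of the 4 values shown sit. The compounds shown leave open how much of any of them is needed for the effect, and whether swapping acetyl for nitro changes that amount at all.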